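Amine variation on the shared core

This account rests on a few compounds, and the source may have more. Where it says the series, first, only, none or still open, it means among the compounds named here.

Measured in an assay on HEK293 cells for inhibition of Steryl-sulfatase (Homo sapiens), tested at 1 uM; a lower number here means a weaker effect, a higher number a stronger effect of the compound at the concentration tested:
compound 1 `CCN(Cc1ccccn1)c1cccc(C(=O)N2CCc3ccc(OS(N)(=O)=O)cc3C2)c1` gives 19.9%
compound 2 `NS(=O)(=O)Oc1ccc2c(c1)CN(C(=O)c1cccc(N3CCCCC3)c1)CC2` gives 11.9%
compound 3 `CCN(Cc1cccc(Br)c1)c1cccc(C(=O)N2CCc3ccc(OS(N)(=O)=O)cc3C2)c1` gives 24.9%

Compound 3 holds the highest of the three numbers in this assay; compound 1 sits within the scatter of it, while compound 2 lies beyond it. The measured steps are a number 8 percentage points lower from compound 1 to compound 2 (within the scatter), a number 5 percentage points higher from compound 1 to compound 3 (within the scatter) and a number 13 percentage points higher from compound 2 to compound 3 (beyond the scatter).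

Compound 4 `CN(CCN1CCCCC1)c1cccc(C(=O)N2CCc3ccc(OS(N)(=O)=O)cc3C2)c1` is the next member. It differs from compound 3 as follows: methyl(2-(piperidin-1-yl)ethyl)amino in place of (3-bromobenzyl)(ethyl)amino on an aromatic carbon.

Among the measured compounds shown here, two steps bear on this change. The step of a number 13 percentage points higher from compound 2 to compound 3 (beyond the scatter) shows that exchanging piperidin-1-yl for the (3-bromobenzyl)(ethyl)amino group raised the number beyond the scatter. The step of a number 5 percentage points higher from compound 1 to compound 3 (within the scatter) shows that swapping the aromatic part of that group stays within the scatter. Compound 4 carries the piperidin-1-yl on a chain and no aromatic ring in the entering group, so the expectation leans toward partly undoing the gain seen in a number 13 percentage points higher from compound 2 to compound 3 (beyond the scatter). A modest decrease is therefore expected, a number 9.9 percentage points lower from compound 3 to compound 4 (within the scatter). For compound 4 the estimate in this assay is 15%, with a range from 5% to 28%.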

Compound 4, a percentage reported as inhibition, at one concentration (the size of the read-out at that concentration, not a potency): 30.8%
Compound 4: middle estimate off by 15.8 percentage points, on the low side; measured number outside the range, above it.
By their numbers in this assay, from the lowest: compounds 2, 1, 3 and 4 (each within the scatter of the next, the first and the last beyond it).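

An aromatic ring in this group is not required at this position on the ring: with methyl(2-(piperidin-1-yl)ethyl)amino, which carries a non-aromatic ring instead, the result is a number 5.9 percentage points higher from compound 3 to compound 4 (within the scatter). The same group is also the first in the series to stand clear of both smaller-effect compounds, with a number 18.9 percentage points higher from compound 2 to compound 4 (beyond the scatter) and a number 10.9 percentage points higher from compound 1 to compound 4 (beyond the scatter), whereas compound 3 stands clear only of compound 2. No supporting data are available to account for these steps.

Compound 4 changes the ring, the chain and the ethyl-to-methyl substituent on nitrogen at once, so the contribution of each remains unresolved. A morpholin-4-yl group in place of the piperidin-1-yl, a dimethylamino group at the chain end or a longer chain between the two nitrogens would help to separate these contributions.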